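The compounds below may be only part of what the source reports. "The series", "measured", "known", "first", "only" and "open" are said of these compounds alone.

Working notes on the benzamide series.

Three compounds have numbers in a functional assay on A-375 cells (Homo sapiens) for antiproliferative activity, read by CCK-8 assay, with a stated time of 72 h, tested at 2 uM; on this read-out lower numbers stand for a weaker effect and higher numbers for a stronger effect at the one concentration tested. Compound 1 `CCN(Cc1ccncc1)C(=S)SCc1ccc(C(=O)Nc2ccccc2N)cc1` gives 67.2%. Compound 2 `Nc1ccccc1NC(=O)c1ccc(CSC(=S)N2CCN(c3ccc(F)cc3)CC2)cc1` gives 20.9%. Compound 3 `Nc1ccccc1NC(=O)c1ccc(CSC(=S)N2CCc3cc(Cl)ccc32)cc1` gives 31.9%. Compound 3 thus holds the second highest of the three numbers: the nearest is compound 2, whose value sits lower by a gap beyond the scatter, and the furthest is compound 1, whose value sits higher by a gap beyond the scatter.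

Among the measured compounds shown here, the one single-point step measured so far runs a number 35.3 percentage points lower from compound 1 to compound 3 (beyond the scatter), with 5-chloro-2,3-dihydro-1H-indol-1-yl in place of ethyl((pyridin-4-yl)methyl)amino on a thiocarbonyl carbon.

Compound 4 `CN1CCN(C(=S)SCc2ccc(C(=O)Nc3ccccc3N)cc2)CC1` has not been measured. It differs from compound 3 by 4-methylpiperazin-1-yl in place of 5-chloro-2,3-dihydro-1H-indol-1-yl on a thiocarbonyl carbon. This is the same position that was varied in the step from compound 1 to compound 3, where the change was large. Compound 2, which also carries a piperazine on that carbon, gives the lowest number of the three, while compound 1, with an open-chain amine, gives the highest. The bearing of these on a 4-methylpiperazin-1-yl group is unclear, so a wide range is kept. Compound 4 is expected to give 40%, within 15% to 65%. The expected change in this assay is a number 8.1 percentage points higher from compound 3 to compound 4 (within the scatter), upward but not confidently beyond the scatter.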

Compound 4, a percentage reported as inhibition, at one concentration (the size of the read-out at that concentration, not a potency): 36.6%
Beside the measured number, compound 4's estimate is 3.4 percentage points above it; measured number inside the range.
By their numbers in this assay, from the lowest: compound 2; then compounds 3 and 4 (each within the scatter of the next); then compound 1.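

In this assay, replacing 5-chloro-2,3-dihydro-1H-indol-1-yl with 4-methylpiperazin-1-yl on the thiocarbonyl carbon gives a number 4.7 percentage points higher from compound 3 to compound 4 (within the scatter), so these two different rings read alike here, while the open-chain group of compound 1 remains clearly ahead of the piperazine, with a number 30.6 percentage points lower from compound 1 to compound 4 (beyond the scatter). Within the piperazine pair, methyl in place of 4-fluorophenyl on an amine nitrogen in a ring gives a number 15.7 percentage points higher from compound 2 to compound 4 (beyond the scatter), which shows for the first time that the group on the far ring nitrogen also affects the read-out, although by less than the change from the open-chain group. No supporting data bear on the reason for any of these differences.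

The compounds shown do not separate the contributions of the ethyl and the pyridin-4-yl parts of the group in compound 1, so the large gap cannot yet be assigned to either part or to the open chain as a whole. A diethylamino group or a benzyl(ethyl)amino group on the thiocarbonyl carbon would address that question, and a piperazine with a free amine nitrogen would extend the comparison between methyl and 4-fluorophenyl.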